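Chloro for fluoro on two cores: kinetic solubility notes

This account rests on a few compounds, and the source may have more. Where it says the series, first, only, none or still open, it means among the compounds named here.

Three members of the series have been measured: compound 1 `CCOC(=O)c1cc(-c2ccc(Cl)cc2)n(-c2ccc(S(N)(=O)=O)cc2)c1`, compound 2 `CCOC(=O)c1cc(-c2ccc(F)cc2)n(-c2ccc(S(N)(=O)=O)cc2)c1` and compound 3 `CCOC(=O)c1cc(-c2ccc(F)cc2)n(-c2ccc(S(N)(=O)=O)cc2)n1`. A fourth, compound 4 `CCOC(=O)c1cc(-c2ccc(Cl)cc2)n(-c2ccc(S(N)(=O)=O)cc2)n1`, awaits measurement. In a physicochemical assay for solubility, read by HPLC, in phosphate buffer, measured as kinetic solubility, at pH 7.4 (on this read-out higher numbers stand for higher solubility and lower numbers for lower solubility), compound 1 gives 10800 nM, compound 2 gives 36400 nM and compound 3 gives 56400 nM. Compound 3 stands highest of the three numbers, but its gap to compound 2 is within the scatter, so no order is claimed between those two; only its gap to compound 1 lies beyond the scatter.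

Compound 2 and compound 3 carry the same substituents on different cores, and the difference between the two cores is not broken down here. Compound 1 differs from compound 2 in one place: chloro in place of fluoro on an aromatic carbon. That change made a 3.4-fold lower number from compound 2 to compound 1 (0.53 log units; beyond the scatter) in this assay. Compound 4 differs from compound 3 in one place as well: chloro in place of fluoro on an aromatic carbon. The place is described identically in both pairs, so the change is the same one, carried onto the core of compound 3.

Among the compounds with values here, with only one measured instance of the change, the expectation rests on the size of a 3.4-fold lower number from compound 2 to compound 1 (0.53 log units; beyond the scatter) applied to the value of compound 3, 56400 nM. The step from compound 3 to compound 4 is therefore expected to be a 3.4-fold lower number from compound 3 to compound 4 (0.53 log units; beyond the scatter) in this assay. Compound 4 is estimated at 16600 nM in this assay. The expected range for compound 4 runs from 8000 nM to 35000 nM.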

Compound 4, solubility: 53300 nM
Compound 4: the middle estimate sits 3.2-fold (0.51 log units) below what was measured, and the stated range ends below it.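

Working notes on the step: in this assay, chloro in place of fluoro on an aromatic carbon gives a 3.4-fold lower number from compound 2 to compound 1 (0.53 log units; beyond the scatter) on the first core, beyond the scatter, whereas on the second core the same change gives a 1.1-fold lower number from compound 3 to compound 4 (0.02 log units; within the scatter) and stays within the scatter, so the step seen on the first core did not carry over to the second. This shows that, for these two matched pairs, the outcome of the 4-fluorophenyl to 4-chlorophenyl change depends on the core that carries it, but with only two instances it does not show which feature of the core matters or how a further core would behave. No supporting measurement bears on why the two pairs part, and the difference stays an observation without an explanation.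

The compounds shown carry only fluoro and chloro at this place, with the ethyl ester and the sulfonamide held fixed throughout, so the reach of the result beyond these four structures is unknown. As far as these compounds go, it remains open whether bromo or methoxy at this place, or a carboxylic acid or an amide in place of the ethyl ester, would follow the pattern of the first core or of the second in this assay.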